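The compounds below may be only part of what the source reports. "The series", "measured", "known", "first", "only" and "open" are said of these compounds alone.

Measured in a functional assay on DU-145 cells (Homo sapiens) for inhibition, read by trypan blue exclusion, with a stated time of 96 h; a lower number here means a stronger inhibitor of growth, a higher number a weaker inhibitor of growth:
Compound 1 `Cc1ccc(S/C(=C/c2ccc(Cl)cc2)C(=O)c2ccc(Br)cc2)cc1`: 10000 nM
Compound 2 `Cc1ccc(S/C(=C/c2c(O)cc(O)cc2O)C(=O)c2ccc(Cl)cc2)cc1`: > 100000 nM

Compound 1 gives a true reading of 10000 nM in this assay. Compound 2 gives > 100000 nM, and this is a limit of the assay, not a number. Compound 2 therefore stands at the limit of > 100000 nM in this assay, at which 1 of the 2 values shown sits. Going by the values given here, the two measured compounds differ in more than one place, so they offer no single measured step to use as a guide.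

Compound 3 `Cc1ccc(S/C(=C/c2c(O)cc(O)cc2O)C(=O)c2ccc(Br)cc2)cc1` is compound 2 with one swap: bromo in place of chloro on an aromatic carbon. The swap sits para to a large group, and the 4-chlorophenyl becomes 4-bromophenyl. The rest of the structure stays the same.

For a swap of this kind, no shift beyond the usual scatter is expected in this assay, in either direction. The estimated change is a number no higher from compound 2 to compound 3 (the limit leaves the size open). Compound 3 is expected to stay in the same weak range as compound 2, and the assay may again report only a limit. The estimated value for compound 3 is 100000 nM, expected to fall between 30000 nM and 300000 nM.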

Compound 3, concentration for 50% growth inhibition: > 100000 nM
Compound 3: a limit, no number; the forecaster's own chance of this, stated with the estimate: 70%; the middle value sits exactly at the limit.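

In this assay compound 3 gives > 100000 nM, which is a limit of the assay and not a number, and the readings now gather at one ceiling: the limit of > 100000 nM in this assay, at which 2 of the 3 values shown sit.

The swap of chloro for bromo on the aromatic carbon cannot be read, since both of its ends are limits, so it shows neither a gain nor a loss at this position. Going by these compounds alone, what is new is the first step with a single change and a readable direction: with the 4-bromophenyl kept in place, 2,4,6-trihydroxyphenyl in place of 4-chlorophenyl on the double-bonded chain carbon gives an at least 10-fold higher number from compound 1 to compound 3 (1.00 log units; beyond the scatter), so this change weakens growth inhibition beyond the usual scatter, and the true size of the loss stays unknown.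

On these data alone, how the 4-chlorophenyl and 4-bromophenyl groups compare therefore remains open, as the shared 2,4,6-trihydroxyphenyl group leaves both compounds at the limit. Also open, as far as these compounds go, is whether a methoxy group or an amine on that ring, in place of the hydroxyl groups, would bring the reading back to a true number.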